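The source may hold more compounds than are shown below. What is called first, only, known or untested is meant among the compounds shown, and "the series" means these compounds.

Measured compounds:
- compound 1 `C[C@]1(C(=O)N2CC[C@](c3ccc(C(F)(C(F)(F)F)C(F)(F)F)cc3)(S(=O)(=O)c3ccc(F)cc3)C2)CC[C@H](C(=O)O)CC1`, an ADME assay on microsomes from liver (Homo sapiens) for metabolic stability, with a stated time of 10 min; a higher number here means that more of the compound is left, a lower number that less of the compound is left: 80%
- compound 2 `O=C(O)[C@H]1CC[C@](F)(C(=O)N2CC[C@](c3ccc(C(F)(C(F)(F)F)C(F)(F)F)cc3)(S(=O)(=O)c3ccc(F)cc3)C2)CC1`, this assay: "not determined" (no result reported)
- compound 3 `O=C(O)C1CCC(O)(C(=O)N2CC[C@](c3ccc(C(F)(C(F)(F)F)C(F)(F)F)cc3)(S(=O)(=O)c3ccc(F)cc3)C2)CC1`, this assay: 100%; 95% (2 entries)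

Compound 2 stands without a number in this assay; its entry carries no result, so its place among the three can only be bracketed by the others. Compound 1 gives 80% in this assay, and compound 3 gives 100%; 95% (2 entries), the two entries of compound 3 sitting within the scatter of each other (the several entries of compound 3 in this assay, 100%; 95% (2 entries)).

Compound 4 `C[C@]1(C(=O)N2CC[C@](c3ccc(C(F)(C(F)(F)F)C(F)(F)F)cc3)(S(=O)(=O)c3ccc(F)cc3)C2)CC[C@@H](C(=O)O)CC1` is not yet measured. It differs from compound 2 in one place (4-carboxy-1-methylcyclohexyl in place of 4-carboxy-1-fluorocyclohexyl on a carbonyl carbon). Within the data shown here, no step between measured compounds carries this change, so its size in this assay is not known from the series; with both measured neighbours high, no step beyond the usual scatter is expected in either direction. Compound 4 is expected at 80% in this assay, between 60% and 97%.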

Compound 4, percent of the compound remaining: 85%
Beside the measured number, compound 4's estimate is 5 percentage points below it; the range from low to high includes it.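

In this assay the series now holds its first readable step, a number 5 percentage points higher from compound 1 to compound 4 (within the scatter). This step concerns configuration alone, with 4-carboxy-1-methylcyclohexyl kept on the carbonyl carbon and the atoms and bonds unchanged: the fact that compounds 1 and 4 differ only in the configuration as drawn. Among these compounds, for this one pair, then, the configuration as drawn at the two saturated ring carbons makes no difference beyond the scatter, which the earlier compounds could not show.

Compound 2 still has no number, so the change from 4-carboxy-1-fluorocyclohexyl to 4-carboxy-1-methylcyclohexyl cannot be read, and neither can any other step to compound 2. Also open, going by these compounds, is how an amine or a methoxy group in place of the methyl of 4-carboxy-1-methylcyclohexyl would stand in this assay, and whether configuration would matter as little with such a group.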